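Moving one chlorine: what compound 4 may show

This account rests on a few compounds, and the source may have more. Where it says the series, first, only, none or still open, it means among the compounds named here.

In a functional assay on A-375 cells (Homo sapiens) for antiproliferative activity, read by MTT assay, with a stated time of 24 h (on this read-out lower numbers stand for stronger inhibition and higher numbers for weaker inhibition), compound 1 `C#CCOc1ccc2c(=O)c(-c3cc(OC)c(OC)cc3OC)coc2c1` gives 3680 nM, compound 2 `COc1cc(OC)c(-c2coc3cc(OCc4ccccc4F)ccc3c2=O)cc1OC` gives 2100 nM, and compound 3 `COc1cc(OC)c(-c2coc3cc(OCc4ccc(Cl)cc4)ccc3c2=O)cc1OC` gives 1020 nM, the lowest of these three numbers. Compound 4 `COc1cc(OC)c(-c2coc3cc(OCc4ccccc4Cl)ccc3c2=O)cc1OC` is still unmeasured and differs from compound 3 by one change: 2-chlorophenyl in place of 4-chlorophenyl on a saturated chain carbon bound to an oxygen on an aromatic ring. Within the data shown here, no measured step moves the chlorine alone. The closest guide is a 2.1-fold lower number from compound 2 to compound 3 (0.31 log units; beyond the scatter), which swaps 2-fluorophenyl for 4-chlorophenyl, while a 3.6-fold lower number from compound 1 to compound 3 (0.56 log units; beyond the scatter) and a 1.8-fold lower number from compound 1 to compound 2 (0.24 log units; within the scatter) show how far the ethynyl replacements reach. Compound 4 carries a 2-substituted ring like compound 2, which gives 2100 nM, so a small rise is expected, probably within the scatter: a 1.5-fold higher number from compound 3 to compound 4 (0.17 log units; within the scatter). For compound 4 the estimated value is 1500 nM, with an expected range of 700 nM to 3200 nM.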

Compound 4, half-maximal inhibitory concentration: 2020 nM
Compound 4: middle estimate off by 1.3-fold (0.13 log units), on the low side; the measured number falls inside the stated range.
By their numbers in this assay, from the lowest: compounds 3, 4, 2 and 1 (each within the scatter of the next, the first and the last beyond it).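

Moving the chlorine alone, the one change not measured before, stays within the scatter (a 2.0-fold higher number from compound 3 to compound 4 (0.30 log units; within the scatter)), so this step shows no clear effect of where the chlorine sits. Chloro in place of fluoro on the 2-substituted ring also stays within it (a 1.0-fold lower number from compound 2 to compound 4 (0.02 log units; within the scatter)), and unlike 4-chlorophenyl, 2-chlorophenyl in place of ethynyl stays within the scatter too (a 1.8-fold lower number from compound 1 to compound 4 (0.26 log units; within the scatter)). Nothing available explains these numbers.

As far as these compounds go, what an amine or a carboxylic acid would do in place of the chlorine remains open.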